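The source may report more compounds than this note shows. Statements on the series, on what has been measured and on what is new or still open speak of the compounds shown alone.

Measured in a functional assay on MDA-MB-468 cells (Homo sapiens) for antiproliferative activity, read by MTT assay, with a stated time of 48 h; on this read-out higher numbers stand for weaker inhibition and lower numbers for stronger inhibition:
compound 1 `COc1cccc(C(=O)Nc2cc3cnc(NCCN(C)C)cc3n(C)c2=O)c1`, 17400 nM
compound 2 `CN(C)CCNc1cc2c(cn1)cc(NC(=O)c1ccccc1)c(=O)n2C`, 18300 nM
compound 3 `CN(C)CCNc1cc2c(cn1)cc(NC(=O)c1ccc(N)cc1)c(=O)n2C`, 20400 nM

Compound 1 holds the lowest of these three numbers, yet the step of a 1.1-fold higher number from compound 1 to compound 2 (0.02 log units; within the scatter) and the step of a 1.2-fold higher number from compound 1 to compound 3 (0.07 log units; within the scatter) both lie within the scatter, so none of the three can be set apart from the others. The unmeasured compound 4 `CN(C)CCNc1cc2c(cn1)cc(NC(=O)c1ccc(Cl)cc1)c(=O)n2C` differs from compound 1 by 4-chlorophenyl in place of 3-methoxyphenyl on a carbonyl carbon. Among the compounds with values here, no measured step introduces a 4-chlorophenyl; the steps that bear on it are the two from compound 1 just named and the step of a 1.1-fold higher number from compound 2 to compound 3 (0.05 log units; within the scatter), every one of them within the scatter. For compound 4 a step no larger than the scatter is therefore expected, a 1.0-fold higher number from compound 1 to compound 4 (0.01 log units; within the scatter). Compound 4 is estimated to give 18000 nM, between 9000 nM and 36000 nM, in this assay.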

Compound 4, half-maximal inhibitory concentration: 1640 nM
Compound 4: the middle estimate sits 11-fold (1.04 log units) above what was measured; measured number below the stated range.
By their numbers in this assay, from the lowest: compound 4; then compounds 1, 2 and 3 (each within the scatter of the next).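

In this assay, the group on this carbonyl carbon proved able to shift the read-out: the earlier changes among 3-methoxyphenyl, phenyl and 4-aminophenyl all stayed within the scatter, but 4-chlorophenyl did not. The change gives an 11-fold lower number from compound 1 to compound 4 (1.03 log units; beyond the scatter), while chloro in place of hydrogen gives an 11-fold lower number from compound 2 to compound 4 (1.05 log units; beyond the scatter) and chloro in place of amino gives a 12-fold lower number from compound 3 to compound 4 (1.09 log units; beyond the scatter). No measurement shown here explains this stronger inhibition. The compounds shown leave open whether chloro is unusual at this place, since none carries bromo, fluoro or methyl in its stead.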